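Swapping the fluorinated aryl ether of compound 1

A few compounds are considered here, and "the series" means these few. Any claim that something is new, unique, unknown or untested is made for them only; others in the source may bear on it.

Compound 1: `CC(C)[C@H](NC(=O)COc1cccc2ccccc12)C(=O)N[C@@H](CC(=O)O)C(=O)COc1ccc(C(F)(F)F)cc1` — > 100000 nM (a limit)
Compound 2: `CC(C)[C@H](NC(=O)COc1cccc2ccccc12)C(=O)N[C@@H](CC(=O)O)C(=O)COc1cc(C(F)(F)F)cc(C(F)(F)F)c1` — > 100000 nM (a limit)
Compound 3: `CC(C)[C@H](NC(=O)COc1cccc2ccccc12)C(=O)N[C@@H](CC(=O)O)C(=O)COc1ccc(OC(F)(F)F)cc1` — 29100 nM

In a functional assay on Jurkat cells (Homo sapiens) (a higher number here means a weaker inhibitor, a lower number a stronger inhibitor), compound 1 gives > 100000 nM, which is a limit of the assay and not a number. Compound 2 likewise gives > 100000 nM, again a limit. Compound 3 gives 29100 nM. As the limit of > 100000 nM in this assay, at which 2 of the 3 values shown sit, shows, compound 1 stands at the weak edge of what has been measured, with only a bound known for it, and it is weaker than compound 3.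

Compound 4, `CC(C)[C@H](NC(=O)COc1cccc2ccccc12)C(=O)N[C@@H](CC(=O)O)C(=O)COc1ccc(F)cc1F`, is not yet measured; it differs from compound 1 by 2,4-difluorophenyl in place of 4-(trifluoromethyl)phenyl on an oxygen on a saturated carbon. Among the measured compounds shown here, the one measured step that bears on this change is an at least 3.4-fold lower number from compound 1 to compound 3 (0.53 log units; beyond the scatter), in which trifluoromethoxy in place of trifluoromethyl on an aromatic carbon brought the value below the limit. For the measured compounds named here, that step is the only guide, and the change to compound 4 is of another kind, so the expected step of an at least 2.2-fold lower number from compound 1 to compound 4 (0.34 log units; beyond the scatter) is small and uncertain, with a fair chance that the assay again reports only a limit. Compound 4 is estimated at 45000 nM, between 10000 nM and 150000 nM.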

Compound 4, half-maximal inhibitory concentration: 33200 nM
Compound 4: the middle estimate sits 1.4-fold (0.13 log units) above what was measured; low and high end bracket the measured number.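

Replacing 4-(trifluoromethyl)phenyl with 2,4-difluorophenyl on the oxygen gives an at least 3.0-fold lower number from compound 1 to compound 4 (0.47 log units; beyond the scatter) in this assay, so a measurable value at this position does not depend on the trifluoromethoxy group. Set against 4-(trifluoromethoxy)phenyl, the new group shows a 1.1-fold higher number from compound 3 to compound 4 (0.06 log units; within the scatter), so these two aryl groups cannot be told apart in this assay, while the two compounds carrying trifluoromethyl, compound 1 and compound 2, stay at the limit. The value of compound 1 is a limit and not a number, so the first step is only a bound on the true size of the change: the limit of > 100000 nM in this assay, at which 2 of the 4 values shown sit.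

The compounds shown leave open whether fluorine on the ring is needed at all, as a plain phenyl group does not appear among them. They also leave open how a nitrile or an amine on that ring would compare.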